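Biaryl Substituent Change in a Bile Acid Receptor Series

The compounds below may be only part of what the source reports. "The series", "measured", "known", "first", "only" and "open" are said of these compounds alone.

Of the compounds shown here, two sharing a common core have been measured in an assay on isolated protein for agonist activity at Bile acid receptor (Homo sapiens), read by AlphaScreen, with a stated time of 30 min; a higher number here means that more compound is needed for the effect, a lower number that less compound is needed. Compound 1 `CCCc1ccccc1-n1nc(C)c2c1NC(=O)[C@H](C)S[C@@H]2c1ccc(Oc2ccccc2)cc1` gives 1100 nM. Compound 2 `COc1ccccc1-c1ccc([C@H]2S[C@@H](C)C(=O)Nc3c2c(C)nn3-c2ccccc2C)cc1` differs from compound 1 in several places at once; in this assay compound 2 gives 1100 nM, level with compound 1 within the usual scatter of this assay.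

Compound 3 `COC(=O)c1ccc(-c2ccc([C@H]3S[C@@H](C)C(=O)Nc4c3c(C)nn4-c3ccccc3C)cc2)cc1` is the next point to be read. Relative to compound 2 the change is a single replacement: 4-(methoxycarbonyl)phenyl in place of 2-methoxyphenyl on an aromatic carbon.

Within the data shown here, no measured pair differing in only one place is available, so the size of this step is uncertain. Since compound 1 and compound 2 give the same value despite differing in several places, the expectation is a small step from compound 2 to compound 3, no change at the digits printed from compound 2 to compound 3 (within the scatter), not beyond the scatter in either direction. Compound 3 is therefore estimated at 1100 nM, with a range from 400 nM to 3500 nM.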

Compound 3, half-maximal effective concentration: "not active" (no number reported)
The entry for compound 3 holds no number; there is nothing to compare the estimate with.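

Among these compounds, compound 3 is recorded as not active, with no number, so no step from compound 2 to compound 3 can be read. The compounds shown leave open how far a single replacement at this place shifts the value in this assay on its own. No measurement shown bears on this result.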